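Adding a methoxy group to a tolerated benzimidazole series

The source may hold more compounds than are shown below. What is called first, only, known or untested is meant among the compounds shown, and "the series" means these compounds.

Of the compounds shown here, three have been tested in an ADME assay on BHK cells (Mesocricetus auratus) for cytotoxicity, read by MTT assay, with a stated time of 96 h; a higher number here means that more compound is tolerated, a lower number that less compound is tolerated. Compound 1 `COc1ccc(-c2nc3cc(C(C)=O)ccc3[nH]2)c(OC)c1` carries an acetyl group on the shared core, and compound 3 `COc1ccc(-c2nc3cc(C(C)=O)ccc3[nH]2)c(OC)c1OC` differs from it by one change, (methoxy in place of hydrogen on an aromatic carbon). Compound 2 `COc1cc(OC)cc(-c2nc3cc(C(F)(F)F)ccc3[nH]2)c1` carries a trifluoromethyl group instead; the difference between the two cores of compound 1 and compound 2 is not broken down here.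

In this assay compound 1 gives a value that is a limit of the assay, > 100000 nM. Compound 3 likewise gives a limit, > 100000 nM. Compound 2 also gives a limit, > 100000 nM. The step that the two limits leave unreadable from compound 1 to compound 3 therefore cannot be sized, because of the limit of > 100000 nM in this assay, at which 3 of the 3 values shown sit.

Compound 4 `COc1cc(-c2nc3cc(C(F)(F)F)ccc3[nH]2)cc(OC)c1OC` has not yet been measured. It differs from compound 2 by methoxy in place of hydrogen on an aromatic carbon. This is the same kind of change as from compound 1 to compound 3, but the place differs: there the new methoxy sat meta to a large group, here it sits para to a large group. Since every measured value sits at the limit, the step that the limit leaves unreadable from compound 2 to compound 4 is expected to stay near zero, and compound 4 is estimated at 150000 nM.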

Compound 4, half-maximal cytotoxic concentration: 31000 nM
For compound 4 the middle estimate is 4.8-fold (0.68 log units) above the measured one; the measured number lies below the stated range.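

In this assay, the added methoxy group gives an at least 3.2-fold lower number from compound 2 to compound 4 (0.50 log units; beyond the scatter), so on the trifluoromethyl core this one change leaves less compound tolerated. Among the compounds shown here, the same kind of change on the acetyl core cannot be read, because neither compound of that pair gives a number, only a limit: the limit of > 100000 nM in this assay, at which 3 of the 4 values shown sit. The result therefore does not show whether the change carries from one core to the other: the acetyl core may or may not respond in the same way, the new methoxy sits in a different place on the ring in each pair, and only one readable step exists.

As far as these compounds go, it remains open whether this drop is particular to methoxy or would also appear with another group in the same place, such as an amine, a carboxylic acid or a longer chain. From the compounds shown here alone, it is also open whether the drop would recur on a core carrying neither trifluoromethyl nor acetyl.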